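The source may hold more compounds than are shown below. What is called first, only, known or untested is meant among the compounds shown, and "the series" means these compounds.

Measured compounds in the series:
- compound 1, `Cc1ccc(-c2c(O)nc3cc(Cl)c([N+](=O)[O-])cc3c2OCCC2CCCCN2)c(C)c1`, 400 nM
- compound 2, `Cc1ccc(-c2c(O)nc3cc(Cl)c(NC(=O)NC4CC4)cc3c2OCCC2CCCCN2)cc1C`, 6 nM
- compound 3, `Cc1cc(C)cc(-c2c(O)nc3cc(Cl)c(NC(=O)c4cnccn4)cc3c2OCCC2CCCCN2)c1`, 1.8 nM

In a functional assay on cells (Pituitary gland cell) for antagonist activity at Gonadotropin-releasing hormone receptor (Rattus norvegicus) (a higher number here means a weaker inhibitor, a lower number a stronger inhibitor), compound 1 gives 400 nM, the highest of the three numbers. Compound 2 gives a lower number, 6 nM, and compound 3 a lower number still, 1.8 nM. Both gaps to compound 1 lie beyond the scatter, so compound 1 is the weakest inhibitor among the three; the difference between compound 2 and compound 3 is not set out as a step here and only the two values speak for it.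

The unmeasured compound 4, `O=[N+]([O-])c1cc2c(OCCC3CCCCN3)c(-c3cccc(F)c3)c(O)nc2cc1Cl`, keeps the whole of compound 1 apart from the group on the shared core: 3-fluorophenyl in place of 2,4-dimethylphenyl on an aromatic carbon.

Among the compounds with values here, no measured pair shows the effect of such a change on this assay. With compound 1 already at the top of the range, a modest shift toward a higher number is expected, likely at the edge of the scatter. Compound 4 is therefore estimated at 1000 nM, within 250 nM to 4000 nM, an expected step of a 2.5-fold higher number from compound 1 to compound 4 (0.40 log units; beyond the scatter).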

Compound 4, half-maximal inhibitory concentration: 53 nM
Beside the measured number, compound 4's estimate is 19-fold (1.28 log units) above it; the whole stated range lies above it.
By their numbers in this assay, from the lowest: compound 3; then compound 2; then compound 4; then compound 1.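

In this assay, the aromatic carbon ortho to the 2-(piperidin-2-yl)ethoxy group is the only place in the series where a single change can be read: 3-fluorophenyl in place of 2,4-dimethylphenyl gives a 7.5-fold lower number from compound 1 to compound 4 (0.88 log units; beyond the scatter). The high number of compound 1 therefore does not belong to the nitro-bearing core alone, since compound 4 keeps that group and gives 53 nM. No measurement shown bears on the reason for this step.

The step combines the loss of both methyl groups with the entry of fluorine, and the compounds shown do not separate these two parts. Open too, on these data alone, are how unsubstituted phenyl or 3-chlorophenyl would compare with 3-fluorophenyl at this position, and whether the step carries over when the nitro group gives way to the urea of compound 2 or the amide of compound 3.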